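Compound 2 as a single stereoisomer: expectation for compound 3

The source may hold more compounds than are shown below. What is called first, only, known or untested is meant among the compounds shown, and "the series" means these compounds.

Measured so far:
compound 1 `Cc1ccc(C2=NN(C(N)=S)C(c3ccc(Cl)cc3)C2)cc1`: 15 nM
compound 2 `NC(=S)N1N=C(c2ccc(F)cc2)CC1c1ccc(Cl)cc1`: 1000 nM

Both compounds were run in an assay on mitochondria for inhibition of Amine oxidase [flavin-containing] B (Bos taurus); on this read-out higher numbers stand for weaker inhibition and lower numbers for stronger inhibition. Among the compounds with values here, compound 2 gives the highest of the two numbers, and its only neighbour is compound 1; the single measured step, a 67-fold higher number from compound 1 to compound 2 (1.82 log units; beyond the scatter), is large and corresponds to fluoro in place of methyl on an aromatic carbon.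

Compound 3 `NC(=S)N1N=C(c2ccc(F)cc2)C[C@H]1c1ccc(Cl)cc1` is the next compound for this assay. Its relation to compound 2 is the two compounds have the same atoms and bonds; at least one stereo element is drawn with a configuration in one of them and without one in the other: 1 of 1 stereo elements differ; a stereocentre at a saturated ring carbon is drawn without a configuration in compound 2 and S in compound 3. In other words, compound 3 is one stereoisomer of the material that compound 2 represents, with no change in atoms or bonds.

Within the data shown here, no measured step bears on a stereo assignment: the step from compound 1 to compound 2 concerns a substituent on an aromatic carbon and gives no guidance here. A single drawn configuration may give a number close to that of compound 2, somewhat lower if it is the more active form, or clearly higher if it is the less active one; the data do not say which. The step of a 1.4-fold lower number from compound 2 to compound 3 (0.15 log units; within the scatter) is therefore expected to stay within the scatter, with wide uncertainty on either side. For compound 3 in this assay the estimate is 700 nM, with a range from 150 nM to 3500 nM.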

Compound 3, inhibition constant: 2400 nM
Estimate against measurement, compound 3: 3.4-fold (0.54 log units) below, within the range that was stated.
By their numbers in this assay, from the lowest: compound 1; then compound 2; then compound 3.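

In this assay, within the data shown here, a 2.4-fold higher number from compound 2 to compound 3 (0.38 log units; beyond the scatter) is the first change at the saturated ring carbon bearing the 4-chlorophenyl group, and it lies beyond the scatter, whereas the earlier step concerned only a substituent on an aromatic carbon. The S drawing therefore gives weaker inhibition than the material drawn without a configuration, so the read-out at this carbon responds to stereochemistry even though the atoms and bonds stay the same. The step can be assigned to the stereocentre alone, because nothing else separates the two structures: the fact that one of compounds 2 and 3 is drawn with a defined configuration and the other without, at the place where they differ.

The composition of compound 2 is not stated, and the R form is absent from the compounds shown, so the size of any gap between the two configurations remains unknown, as does whether the S drawing would raise the number in the same way with the methyl group of compound 1 in place of fluoro. Also open, going by these compounds, is how the S form would respond to a methoxy group in place of fluoro on the aromatic carbon, or to a carbonyl in place of the thiocarbonyl.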